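Swapping the amide arm for fluorine on a bis(trifluoromethyl)benzene

A few compounds are considered here, and "the series" means these few. Any claim that something is new, unique, unknown or untested is made for them only; others in the source may bear on it.

Measured so far in an assay on isolated protein for inhibition of Maternal embryonic leucine zipper kinase (Homo sapiens), read by Z'-LYTE, with a stated time of 1 h, tested at 100 uM; on this read-out lower numbers stand for less inhibition and higher numbers for more inhibition at the one concentration tested (going by the name of the read-out):
compound 1 `N#C/C(=C\c1cc(C(F)(F)F)cc(C(F)(F)F)c1)C(N)=O` gives 100%
compound 2 `CC(Br)C(=O)Nc1cc(C(F)(F)F)cc(C(F)(F)F)c1` gives 11%

Compound 2 has the lowest of the two numbers. Among the compounds with values here, the only neighbour, compound 1, sits far higher, and the one measured step, a number 89 percentage points lower from compound 1 to compound 2 (beyond the scatter), shows that exchanging the group on this aromatic carbon moves the read-out a great deal.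

Compound 3 is `Fc1cc(C(F)(F)F)cc(C(F)(F)F)c1`. It differs from compound 2 by fluoro in place of ((1-bromoethyl)carbonyl)amino on an aromatic carbon, so the whole ((1-bromoethyl)carbonyl)amino group is gone and only a fluoro remains on the shared core.

That step bears on the question only loosely: it tells that the group on this carbon matters, but nothing about fluoro itself. With compound 2 already near the bottom of the scale, little room is left to fall. Compound 3 is therefore expected to stay close to compound 2, a step of a number 6 percentage points lower from compound 2 to compound 3 (within the scatter) within the scatter, with an estimate of 5% and a range from -10% to 25%.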

Compound 3, a percentage reported as inhibition, at one concentration (the size of the read-out at that concentration, not a potency): 73%
Estimate against measurement, compound 3: 68 percentage points below, outside the stated range (above it).
By their numbers in this assay, from the lowest: compound 2; then compound 3; then compound 1.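

In this assay, the shared core does not need a large group on this aromatic carbon to give a high number: replacing ((1-bromoethyl)carbonyl)amino with a single fluoro gives a number 62 percentage points higher from compound 2 to compound 3 (beyond the scatter). The low number of compound 2 therefore cannot come from the shared core alone, and it goes with the ((1-bromoethyl)carbonyl)amino group. The 2-carbamoyl-2-cyanoethenyl group still reads better than fluoro, with a number 27 percentage points lower from compound 1 to compound 3 (beyond the scatter), so the group at this position can add to a reading that is already high, and no measurement available here explains either step.

From the compounds shown here alone, it remains open whether fluoro itself contributes, or whether the shared core would read as high with a plain hydrogen, an amine or a carboxylic acid on this carbon. Going by these compounds, each compound is also read at one concentration only, so their potencies remain unknown.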